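Swapping Acetyl for Dimethylamino on a Growth Inhibitor

The source may hold more compounds than are shown below. What is called first, only, known or untested is meant among the compounds shown, and "the series" means these compounds.

Compound 1 `COc1cc(C)cc(-c2c(-c3ccnc(-c4ccc(C(C)=O)cc4)c3)cnn2CC#N)c1` was tested in a functional assay on Malme-3M cells (Homo sapiens) for inhibition, read by sulforhodamine B assay, with a stated time of 48 h; a higher number here means a weaker inhibitor of growth, a lower number a stronger inhibitor of growth. Compound 1 gave only a limit there, > 100000 nM, so its true value is not known as a number. Compound 2 `Cc1cc(O)cc(-c2nn(CC#N)cc2-c2ccnc(-c3ccc(N(C)C)cc3)c2)c1` also carries a dimethylamino group but differs in more than one place, and in this assay compound 2 gives 39200 nM. For the measured compounds named here, no step between these two measured compounds can be drawn, so their two values can only be set side by side. Compound 3 `COc1cc(C)cc(-c2c(-c3ccnc(-c4ccc(N(C)C)cc4)c3)cnn2CC#N)c1` differs from compound 1 by dimethylamino in place of acetyl on an aromatic carbon. Compound 1 stands at the edge of what the assay can report, as shown by the limit of > 100000 nM in this assay, at which 1 of the 2 values shown sits, so any step to compound 3 starts from a limit rather than from a number. The change is expected to bring compound 3 to stronger growth inhibition than that limit, a step estimated at an at least 1.8-fold lower number from compound 1 to compound 3 (0.25 log units; that floor lies within the scatter). Compound 3 is expected to land near 55000 nM, between 20000 nM and 100000 nM. This expectation rests on compound 2, which with the same dimethylamino group gives 39200 nM.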

Compound 3, concentration for total growth inhibition: > 100000 nM
Compound 3: no number, only a limit; the forecaster's own chance of this, stated with the estimate: 35%; middle value at least 1.8-fold (0.25 log units) away from the limit.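

In this assay compound 3 gives > 100000 nM, a limit and not a number. Compound 1 also stands at a limit, so no step between compound 1 and compound 3 can be read: the limit of > 100000 nM in this assay, at which 2 of the 3 values shown sit.

The compounds shown leave open whether dimethylamino in place of acetyl changes growth inhibition at all, and by how much.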